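The source may hold more compounds than are shown below. What is called first, only, known or untested is meant among the compounds shown, and "the series" means these compounds.

Compounds measured so far:

Compound 1 `CCC(/C=C1\OC(=O)NC1=O)(CC)c1ccc(-c2ccc3cccc(F)c3c2)[nH]c1=O`, with 13 nM in an assay on membranes from Chem-1 cells for displacement of a labelled ligand from prostaglandin E2 receptor EP3 subtype (Homo sapiens), read by scintillation counting, with a stated time of 2 h; a higher number here means a weaker inhibitor, a lower number a stronger inhibitor.
Compound 2 `CCC(/C=C1\OC(=O)NC1=O)(CC)c1ccc(-c2ccc3cccc(C(F)(F)F)c3c2)[nH]c1=O`, with 230 nM in this assay.

Compound 1 holds the lowest of the two numbers in this assay; the nearest is compound 2, reached by an 18-fold higher number from compound 1 to compound 2 (1.25 log units; beyond the scatter), where the change is a trifluoromethyl in place of fluoro on an aromatic carbon. Compound 3 `CCC(/C=C1\OC(=O)NC1=O)(CC)c1ccc(-c2ccc3cc(F)cc(F)c3c2)[nH]c1=O` has not been measured. It differs from compound 1 by fluoro in place of hydrogen on an aromatic carbon. Going by the values given here, the only measured step, from compound 1 to compound 2, replaces the fluoro itself and is therefore a different kind of change; it shows that this part of the molecule can move the number a lot, but it does not tell how a second fluoro on the fused ring behaves. With the fluoro of compound 1 kept in place, a small step is expected, a 1.5-fold higher number from compound 1 to compound 3 (0.19 log units; within the scatter), likely within the scatter. Compound 3 is estimated at 20 nM, between 6 nM and 70 nM.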

Compound 3, inhibition constant: 28 nM
Estimate against measurement, compound 3: 1.4-fold (0.15 log units) below; measured number inside the range.
By their numbers in this assay, from the lowest: compound 1; then compound 3; then compound 2.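

Adding a fluoro on this aromatic carbon, meta to the fluoro group already present, gives a 2.2-fold higher number from compound 1 to compound 3 (0.33 log units; beyond the scatter) in this assay and so counts as a modest step. Going by these compounds alone, the one earlier step replaced the existing fluoro, whereas this one shows that a carbon bearing only hydrogen in compound 1 also affects the number when substituted, and that the change here is small. No available data explain why the added fluoro shifts the number in this direction.

The compounds shown leave open whether a chloro, a methoxy, a nitrile or an amine on this same carbon would move the number further or in the opposite direction. They also leave open whether this fluoro would give a step of similar size without the fluoro of compound 1 in place.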